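This account rests on a few compounds, and the source may have more. Where it says the series, first, only, none or still open, it means among the compounds named here.

Measured compounds:
compound 1, `Cc1ccc2c(c1)c([N+](=O)[O-])cc[n+]2[O-]`: 1.24
compound 2, `O=[N+]([O-])c1cc[n+]([O-])c2ccc(Cl)cc12`: 1.4
compound 3, `Cc1c[n+]([O-])c2ccccc2c1[N+](=O)[O-]`: 1.24

In a physicochemical assay for lipophilicity (a lower number here means a more polar compound, a higher number a more lipophilic compound), compound 1 gives 1.24, compound 2 gives 1.4 and compound 3 gives 1.24. From compound 1 to compound 2 the change is chloro in place of methyl on an aromatic carbon and the step is a number 0.16 log units higher from compound 1 to compound 2 (within the scatter). Compound 3 reads level with compound 1 at the digits given; the difference between the two cores is not broken down here. Compound 4, `O=[N+]([O-])c1c(Cl)c[n+]([O-])c2ccccc12`, awaits measurement and differs from compound 3 by chloro in place of methyl on an aromatic carbon. This is the same kind of change, at a different place: in compound 2 it sits on a six-membered aromatic ring of carbon only, meta to a fused ring and para to a fused ring; in compound 4 on a six-membered aromatic ring with 1 nitrogen, ortho to a nitro group, two atoms from the ring nitrogen, meta to a group of 1 heavy atom, meta to a fused ring and para to a fused ring. For compound 4 the expected step is a number 0.16 log units higher from compound 3 to compound 4 (within the scatter), resting on a number 0.16 log units higher from compound 1 to compound 2 (within the scatter). Compound 4 is accordingly estimated at 1.4, between 1.1 and 1.7.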

Compound 4, partition coefficient: 1.33
Compound 4: middle estimate off by 0.07 log units, on the high side, within the range that was stated.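

In this assay, chloro in place of methyl on an aromatic carbon gives a number 0.09 log units higher from compound 3 to compound 4 (within the scatter) and, on the other core, a number 0.16 log units higher from compound 1 to compound 2 (within the scatter) and so, in both pairs, the change carries over without a step that stands clear of the scatter. Two steps of this kind fix no firm size for the change and do not separate the two places, so they show no more than that neither pair gives a clear step. Nothing available bears on the reason for this result.

The compounds shown leave open how an amine, a carboxylic acid or a longer chain would read in place of methyl on either core. They also leave open how chloro in place of methyl reads at other places on these cores.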